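This account rests on a few compounds, and the source may have more. Where it says the series, first, only, none or still open, it means among the compounds named here.

Compound 2 `O=C(C1CC2(CCN(C3CCOCC3)CC2)C1)N1CCN(C2CCC2)CC1` has been measured in an ADME assay (liver) for metabolic stability, with Liver microsome (Rattus norvegicus) as the target, using microsomes; a lower number here means slower removal, a higher number faster removal of the compound. Compound 2 gives < 4 mL.min-1.g-1, which is a limit of the assay and not an exact number. Among the measured compounds shown here, the only other measured compound is compound 1 `O=C(C1CC12CCN(C1CCOCC1)CC2)N1CCN(C2CC2)CC1`, and in this assay compound 1 gives 20 mL.min-1.g-1. These two compounds differ in more than one place, so their values cannot be tied to any single change.

Compound 3 `CC(C)N1CCN(C(=O)C2CC3(CCN(C4CCOCC4)CC3)C2)CC1` keeps the core of compound 2 and alters one group: isopropyl in place of cyclobutyl on an amine nitrogen in a ring. For the measured compounds named here, no measured pair shows what this swap does in this assay, so any forecast is tentative. Going by the values given here, the swap touches only this one group, and the group that enters is also a small carbon group. The expected change an at least 1.2-fold higher number from compound 2 to compound 3 (0.09 log units; that floor lies within the scatter) is therefore small and, if anything, towards faster removal. Compound 3 could also turn out to be reported only as a limit. For compound 3 the estimated value is 5 mL.min-1.g-1, with an expected range from 2 mL.min-1.g-1 to 12 mL.min-1.g-1.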

Compound 3, intrinsic clearance in microsomes in the Liver microsome assay: < 4 mL.min-1.g-1
Compound 3: no number, only a limit; the forecaster's own chance of this, stated with the estimate: 40%; middle value at least 1.2-fold (0.09 log units) away from the limit.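

Among the compounds shown here, compound 2 and compound 3 are both reported only as limits of the assay, in the Liver microsome assay and also in a physicochemical assay for solubility, measured as thermodynamic solubility, at pH 7.4; on this read-out higher numbers stand for higher solubility and lower numbers for lower solubility; no step between them can be read in either. In the physicochemical assay compound 2 gives > 500000 nM, which is a limit of the assay. In the physicochemical assay compound 3 gives > 500000 nM, which is also a limit of the assay. The compounds shown leave open whether isopropyl in place of cyclobutyl on an amine nitrogen in a ring changes either read-out at all, and by how much.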